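The compounds below may be only part of what the source reports. "The series", "measured", "known", "first", "only" and "open" are said of these compounds alone.

Compound 1, with the structure `ClCc1ccc(Cn2cnc3c(Cl)ncnc32)cc1`, holds the lower of the two numbers recorded so far in a functional assay on HOP-62 cells (Homo sapiens) for cytotoxicity, read by sulforhodamine B assay, with a stated time of 48 h; on this read-out lower numbers stand for higher toxicity in this test and higher numbers for lower toxicity in this test. In this assay compound 1 gives 32400 nM. For the measured compounds named here, its only measured companion is compound 2, with the structure `ClCc1ccccc1Cn1cnc2ncnc(Cl)c21`, which in this assay gives 75900 nM; the gap between the two numbers is stated to lie beyond the usual scatter, so compound 1 is the more toxic of the pair in this test. Going by the values given here, no step between two measured compounds that differ in a single place is available, so nothing measured speaks directly to the change under consideration.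

Compound 3, with the structure `ClCc1ccc(Cn2cnc3c(Cl)nc(Cl)nc32)cc1`, has not yet been measured. It differs from compound 1 by chloro in place of hydrogen on an aromatic carbon, a chloro in place of hydrogen on an aromatic carbon. Among the compounds with values here, with no comparable step among the measured compounds, the expected step from compound 1 to compound 3 in this assay, a 1.1-fold lower number from compound 1 to compound 3 (0.03 log units; within the scatter), is set at none beyond the scatter. On that basis compound 3 is estimated to give about 30000 nM in this assay, with a range from 12000 nM to 80000 nM.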

Compound 3, concentration lethal to 50% of the cells: 19500 nM
For compound 3 the middle estimate is 1.5-fold (0.19 log units) above the measured one; the range from low to high includes it.
By their numbers in this assay, from the lowest: compounds 3 and 1 (each within the scatter of the next); then compound 2.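

For the compounds shown here, this is the first step that changes a single place: chloro in place of hydrogen on an aromatic carbon, between two ring nitrogen atoms and on the six-membered aromatic ring with 2 nitrogen. In this assay that step reads a 1.7-fold lower number from compound 1 to compound 3 (0.22 log units; within the scatter), so this one change leaves no difference that can be told from the usual scatter of repeated measurements, and hydrogen and chloro at this place read alike in this test. Nothing measured on these compounds offers an explanation for this result.

What stays open is whether a different group at the same place, such as an amine or a methoxy group, would also stay within the scatter of compound 1, as chloro is the only replacement for hydrogen shown there. It is also open whether the same chloro in place of hydrogen would give a step of similar size on compound 2, the companion that has no such counterpart among the compounds shown.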